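The compounds below may be only part of what the source reports. "The series", "measured", "known", "first", "only" and "open" are said of these compounds alone.

Three diaryl ureas have been tested in an assay on isolated protein for inhibition of serine/threonine-protein kinase TNNI3K (Homo sapiens); on this read-out higher numbers stand for weaker inhibition and lower numbers for stronger inhibition. Compound 1 `CNc1cc(Oc2ccc(NC(=O)Nc3ccccc3)cc2)ncn1` gives 6300 nM in this assay. Compound 2 `O=C(Nc1ccc(Oc2ccncn2)cc1)Nc1cccc(C(F)(F)F)c1` gives 160 nM in this assay. Compound 3 `CNc1cc(Oc2c(C)cc(NC(=O)Nc3cccc(C(F)(F)F)c3)cc2C)ncn1` gives 25 nM in this assay. Among these three numbers compound 2 holds the second highest: compound 3 sits lower by a margin beyond the usual scatter, and compound 1 sits higher by a larger margin, also beyond the scatter.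

Compound 4 `CNc1nccc(Oc2ccc(NC(=O)Nc3cccc(C(F)(F)F)c3)cc2)n1` has not yet been measured. It differs from compound 2 in one place: methylamino in place of hydrogen on an aromatic carbon of a six-membered aromatic ring with two nitrogens, between two ring nitrogen atoms. Among the compounds with values here, no pair of measured compounds differs by exactly this change, so the size of the step rests on judgement alone. A small step toward stronger inhibition, possibly not beyond the scatter, is expected from compound 2 to compound 4, namely a 1.6-fold lower number from compound 2 to compound 4 (0.20 log units; within the scatter). For compound 4 the expected value in this assay is 100 nM, with a likely range from 30 nM to 400 nM.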

Compound 4, half-maximal inhibitory concentration: 50 nM
Estimate against measurement, compound 4: 2.0-fold (0.30 log units) above; measured number inside the range.
By their numbers in this assay, from the lowest: compounds 3 and 4 (each within the scatter of the next); then compound 2; then compound 1.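

Within the data shown here, putting methylamino in place of hydrogen on an aromatic carbon, between two ring nitrogen atoms, brings a 3.2-fold lower number from compound 2 to compound 4 (0.51 log units; beyond the scatter) in this assay and so gives a first reading of this position. The step is modest, but it shows that this carbon can carry a group larger than hydrogen without any loss of inhibition, and in this pair inhibition gets stronger. No measurement at hand bears on why the number falls.

From the compounds shown here alone, whether this gain needs methylamino in particular stays open, since a plain amino group, a methoxy group or the longer ethylamino chain on this carbon would be needed to tell. A single pair also leaves open whether the same change would help on the other ureas.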